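The source may report more compounds than this note shows. Statements on the series, on what has been measured and on what is new or still open speak of the compounds shown alone.

Measured so far:
compound 1, `Cc1nc(SCC(=O)Nc2nc(-c3ccc(Cl)cc3)cs2)n(Nc2ccccc2)c1C`, 2890 nM
compound 2, `Cc1ccc(Nn2c(SCC(=O)Nc3nc(-c4ccccc4)cs3)nc(C)c2C)cc1`, 3880 nM

Of the compounds shown here, two have been tested in a functional assay on NCI-H460 cells (Homo sapiens) for antiproliferative activity, read by sulforhodamine B assay, with a stated time of 48 h; a lower number here means a stronger inhibitor of growth, a higher number a weaker inhibitor of growth. Compound 1 gives 2890 nM, and compound 2, which differs from it in several places, gives 3880 nM; the two numbers lie within the usual scatter of each other, so neither can be called the stronger growth inhibitor on this evidence. Compound 3, `COc1ccc(Nn2c(SCC(=O)Nc3nc(-c4ccc(Cl)cc4)cs3)nc(C)c2C)cc1`, has not yet been measured in this assay. It differs from compound 1 by methoxy in place of hydrogen on an aromatic carbon. Within the data shown here, no pair of measured compounds shows this single change on its own, so there is nothing to read a step from. Given that compound 2 carries a small group at the same position and still sits within scatter of compound 1, the step from compound 1 to compound 3 is expected to be small, with no clear direction beyond the scatter, as a 1.1-fold lower number from compound 1 to compound 3 (0.03 log units; within the scatter). Compound 3 is accordingly estimated at 2700 nM, within a range of 1100 nM to 6500 nM.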

Compound 3, concentration for 50% growth inhibition: 2690 nM
Estimate against measurement, compound 3: 1.0-fold (0.00 log units) above; low and high end bracket the measured number.
By their numbers in this assay, from the lowest: compounds 3, 1 and 2 (each within the scatter of the next).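

In this assay, the swap of hydrogen for methoxy on the aromatic carbon para to a large group gives a 1.1-fold lower number from compound 1 to compound 3 (0.03 log units; within the scatter). Among these compounds, this is the first pair that differs in one place only, and it shows that phenyl and 4-methoxyphenyl cannot be told apart here: the position can carry this group with no step beyond the scatter. Nothing measured on these compounds beyond growth inhibition is available to account for this result.

On these data alone, a single substituent at one position says little about that position in general, so it remains open whether an amine, a carboxylic acid or a longer chain such as butoxy would also leave the number within the scatter. The same question stands for methoxy on the other carbons of this ring.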